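A few compounds are considered here, and "the series" means these few. Any claim that something is new, unique, unknown or untested is made for them only; others in the source may bear on it.

Working notes on the series in a functional assay on the whole organism (strain Kunming) with Mus musculus as the target, in the maximal electroshock model; on this read-out higher numbers stand for an effect only at larger amounts of compound and lower numbers for an effect already at smaller amounts:

- compound 1 `O=C(/C=C/c1ccc(F)cc1)NCCO`: 45.6 mg/kg
- compound 2 `O=C(/C=C/c1cccc(F)c1)NCCO`: 17 mg/kg
- compound 3 `O=C(/C=C/c1cccc(Cl)c1)NCCO`: 25 mg/kg
- compound 4 `CN(C)c1ccc(/C=C/C(=O)NCCO)cc1`: not yet measured

The number of compound 1 lies within the scatter of that of compound 3 and beyond the scatter above that of compound 2. The next change starts from compound 1: dimethylamino in place of fluoro on an aromatic carbon, para to a group of 8 heavy atoms (dimethylamino in place of fluoro on an aromatic carbon).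

Among the compounds with values here, only one measured step bears on this, and only loosely. It is a 1.5-fold higher number from compound 2 to compound 3 (0.17 log units; within the scatter), with chloro in place of fluoro on an aromatic carbon. Within the data shown here, that step stays within the scatter, but it does not start from compound 1, and no measured compound carries dimethylamino. Compound 1 and compound 2 both carry fluoro, at different places, and their values differ beyond the scatter, so the data give no direct guide to a replacement at the place it occupies in compound 1.

With no direction supported, no step beyond the scatter is expected, and the estimated step is a 1.1-fold lower number from compound 1 to compound 4 (0.06 log units; within the scatter). The uncertainty remains wide. For compound 4 the expected value is 40 mg/kg, with an estimated range from 15 mg/kg to 110 mg/kg.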

Compound 4, dose for half-maximal effect: 66.1 mg/kg
The estimate for compound 4 lay 1.7-fold (0.22 log units) below the measured number, within the range that was stated.
By their numbers in this assay, from the lowest: compounds 2, 3, 1 and 4 (each within the scatter of the next, the first and the last beyond it).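

In this assay, replacing fluoro with dimethylamino on the aromatic carbon para to a group of 8 heavy atoms gives a 1.4-fold higher number from compound 1 to compound 4 (0.16 log units; within the scatter). Within the data shown here, this is the first reading at this place: the only earlier step, chloro in place of fluoro, started from compound 2 and not from compound 1. In this single pair, a group of 3 heavy atoms with 1 hydrogen-bond acceptor replaces a single fluorine atom without a shift beyond the scatter, although one pair cannot define what the position accepts, and no supporting measurement is available to account for the result.

The compounds shown leave open whether other groups at this place, such as a carboxylic acid, a methoxy group or a longer alkyl chain, would also stay within the scatter of compound 1. They also leave open whether dimethylamino would give a similar step from compound 2, where fluoro occupies a different place on the ring and the starting number in this assay is 17 mg/kg.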